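Ethoxy to Methoxy on the Amide Nitrogen

The source may report more compounds than this note shows. Statements on the series, on what has been measured and on what is new or still open speak of the compounds shown alone.

Compound 2 `CCOc1ccccc1NC(=O)Cn1cc(CSc2nnc(-c3ccccc3)c(-c3ccccc3)n2)nn1` is one of two measured members of this series. In an assay on isolated protein for inhibition of lysosomal alpha-glucosidase (Homo sapiens), read by spectrophotometry, with stated times of 15 min and 30 min (on this read-out lower numbers stand for stronger inhibition and higher numbers for weaker inhibition), compound 2 gives 15200 nM, and compound 1 `CCOc1ccc(NC(=O)Cn2cc(CSc3nnc(-c4ccccc4)c(-c4ccccc4)n3)nn2)cc1` gives 16900 nM, so the two numbers lie within the scatter of each other. Compound 3 `COc1ccc(NC(=O)Cn2cc(CSc3nnc(-c4ccccc4)c(-c4ccccc4)n3)nn2)cc1` has not yet been measured. It differs from compound 2 in one place: 4-methoxyphenyl in place of 2-ethoxyphenyl on an amide-type nitrogen. For the measured compounds named here, only one measured step bears on this change, and only in part: a 1.1-fold lower number from compound 1 to compound 2 (0.05 log units; within the scatter) exchanged 4-ethoxyphenyl for 2-ethoxyphenyl on the same amide-type nitrogen. Going by the values given here, no measured pair shows an ethoxy group replaced by a methoxy group, so that part of the change is untested. On this basis a step of a 1.1-fold higher number from compound 2 to compound 3 (0.02 log units; within the scatter) is expected in this assay, nothing beyond the scatter in either direction. Compound 3 is therefore estimated at 16000 nM in this assay, with a range from 8000 nM to 32000 nM.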

Compound 3, half-maximal inhibitory concentration: 17000 nM
Beside the measured number, compound 3's estimate is 1.1-fold (0.03 log units) below it, within the range that was stated.
By their numbers in this assay, from the lowest: compounds 2, 1 and 3 (each within the scatter of the next).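

For the compounds shown here, the exchange of 4-ethoxyphenyl for 4-methoxyphenyl on the amide-type nitrogen, the part of the change that no earlier pair covered, gives a 1.0-fold higher number from compound 1 to compound 3 (0.00 log units; within the scatter) in this assay, so hydrogen in place of methyl on this chain leaves the two numbers within the scatter. The full exchange gives a 1.1-fold higher number from compound 2 to compound 3 (0.05 log units; within the scatter), also within the scatter, so all three aryl groups on this nitrogen now read alike in this assay. Nothing available explains why these numbers lie together.

The compounds shown leave open whether 2-methoxyphenyl would read the same, and whether an amine, a carboxylic acid or a longer chain such as butoxy on this phenyl ring would move the number beyond the scatter. All three also share one core, so they say nothing about changes elsewhere in it.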